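Replacing the Fused Bicyclic Amine with Dibutylamino

A few compounds are considered here, and "the series" means these few. Any claim that something is new, unique, unknown or untested is made for them only; others in the source may bear on it.

In an assay on HeLa cells for inhibition of Indoleamine 2,3-dioxygenase 1 (Homo sapiens), with stated times of 1 h and 18 h (on this read-out lower numbers stand for stronger inhibition and higher numbers for weaker inhibition), the two measured compounds gave:
Compound 1 `CCN(c1ccc(-c2ccccc2C(=O)O)cc1NC(=O)Nc1ccc(C)cc1)C1CCCC1`: 23 nM
Compound 2 `Cc1ccc(NC(=O)Nc2cc(-c3ccccc3C(=O)O)ccc2N2CCC[C@@H]3CCCC[C@@H]32)cc1`: 159 nM

Within the data shown here, compound 2 stands at the higher of the two numbers, the weaker inhibitor of the pair; the only measured step, a 6.9-fold higher number from compound 1 to compound 2 (0.84 log units; beyond the scatter), separates it from compound 1, and that step exchanged the amine group on the same aromatic carbon that is varied next. Compound 3 `CCCCN(CCCC)c1ccc(-c2ccccc2C(=O)O)cc1NC(=O)Nc1ccc(C)cc1` carries the change (a group of 9 heavy atoms (8 carbon, 1 nitrogen; no ring) in place of a group of 10 heavy atoms (9 carbon, 1 nitrogen; one six-membered non-aromatic ring of carbon only, one six-membered non-aromatic ring with 1 hetero atom), on an aromatic carbon). Among the measured compounds shown here, the one step that bears on this is the step from compound 1 to compound 2, which was modest, and it shows that the amine group at this position shifts the number noticeably. For the measured compounds named here, no measured compound carries an open-chain amine of this kind, so the direction rests on a single comparison. The expectation is a move back toward a lower number, a 2.7-fold lower number from compound 2 to compound 3 (0.42 log units; beyond the scatter). Compound 3 is therefore estimated at 60 nM, within a range of 15 nM to 250 nM.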

Compound 3, half-maximal inhibitory concentration: 45 nM
Compound 3: middle estimate off by 1.3-fold (0.12 log units), on the high side; measured number inside the range.
By their numbers in this assay, from the lowest: compounds 1 and 3 (each within the scatter of the next); then compound 2.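

In this assay the swap of the fused two-ring amine for open-chain dibutylamino gives a 3.5-fold lower number from compound 2 to compound 3 (0.55 log units; beyond the scatter) and so shows that a ring in the amine is not required at this aromatic carbon, since the amine without any ring does better here than the two-ring amine of compound 2. Set against the other open-chain-bearing amine, the change gives a 2.0-fold higher number from compound 1 to compound 3 (0.29 log units; within the scatter) and this lies within the scatter, so dibutylamino and cyclopentyl(ethyl)amino cannot be ranked, and only the two-ring amine stands apart. Nothing available explains why the number moves with these amines.

Going by these compounds, whether a shorter chain, as in diethylamino, would keep the number remains open. So does the effect of a single-ring amine such as piperidine at this same carbon.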